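Fluorines on the Second Ring of a Furazano-Fused Core

The compounds below may be only part of what the source reports. "The series", "measured", "known", "first", "only" and "open" are said of these compounds alone.

Measured so far in an assay on mitochondria from L6 cells (Rattus norvegicus) for activation, with a stated time of 90 min; a higher number here means that more compound is needed for the effect, a lower number that less compound is needed:
- compound 1 `FC(F)(F)Oc1ccc(Nc2nc3nonc3nc2Nc2ccc(OC(F)(F)F)cc2)cc1`, for which this assay gives only a limit, < 5000 nM
- compound 2 `FC(F)(F)c1ccccc1Nc1nc2nonc2nc1Nc1ccccc1C(F)(F)F`, which gives 1000 nM
- compound 3 `Fc1ccccc1Nc1nc2nonc2nc1Nc1ccccc1`, which gives 2200 nM

Among the two actual numbers, compound 3 stands highest, so more of it is needed than of compound 2; the gap between them lies beyond the usual scatter of repeated measurements, so the ranking is real. The value of compound 1 is a limit of the assay and not a number.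

Compound 4 `Fc1ccccc1Nc1nc2nonc2nc1Nc1cccc(F)c1F` differs from compound 3 in one place: 2,3-difluorophenyl in place of phenyl on a nitrogen on an aromatic ring. Compound 3 already carries one fluorine on its other ring, and compound 2 carries a substituted ring on both sides. Filling the bare ring of compound 3 with two fluorines is expected to bring compound 4 a small step down in this assay, toward the number of compound 2, probably not far beyond the scatter. Compound 4 is expected at 1500 nM, with a range from 500 nM to 4500 nM. That estimate amounts to an expected step of a 1.5-fold lower number from compound 3 to compound 4 (0.17 log units; within the scatter).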

Compound 4, half-maximal effective concentration: 500 nM
Beside the measured number, compound 4's estimate is 3.0-fold (0.48 log units) above it; the measured number falls inside the stated range.
By their numbers in this assay, from the lowest: compounds 4 and 2 (each within the scatter of the next); then compound 3.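

For the compounds shown here, until this point, no two measured compounds differed in only one place, so no single change could be read in this assay. Replacing phenyl with 2,3-difluorophenyl on a nitrogen on an aromatic ring now gives the first such reading, a 4.4-fold lower number from compound 3 to compound 4 (0.64 log units; beyond the scatter), showing that this position responds to substitution, with the rest of the molecule held the same. Compound 1 sits at a limit of the assay and has no actual number, so it adds no step here: the limit of < 5000 nM in this assay, at which 1 of the 4 values shown sits.

The compounds shown cannot separate the contributions of the two fluorines, so it remains open whether either one alone would give the same step. From the compounds shown here alone, what a different group on this ring would do, such as a methoxy group, an amine or a carboxylic acid, also remains open.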